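Swapping a Phenyl for Furan-2-yl on a Fused Core

A few compounds are considered here, and "the series" means these few. Any claim that something is new, unique, unknown or untested is made for them only; others in the source may bear on it.

Compound 1 `CN1C[C@@H](c2ccccc2)[C@@]2(Cc3ccccc3C2=O)[C@@]12C(=O)Nc1ccccc12`: 40%
Compound 2 `CN1C(=O)[C@@]2(c3ccccc31)N(C)C[C@@H](c1ccc(Cl)cc1)[C@@]21Cc2ccccc2C1=O`: 36.3%
Compound 3 `Cc1ccc([C@@H]2CN(C)[C@]3(C(=O)N(C)c4ccccc43)[C@]23Cc2ccccc2C3=O)cc1`: 8%

All three compounds were tested in a functional assay on the whole organism (strain Wister albino) for inhibition, with Rattus norvegicus as the target, read by paw edema, with stated times of 1 h and 2 h, at a dose of 50 mg/kg by the intraperitoneal route; a higher number here means more inhibition at the dose given (going by the name of the read-out), a lower number less inhibition. Compound 1 gives 40%, the highest of the three numbers, but compound 2 with 36.3% lies within the usual scatter of it, so the two cannot be told apart. Compound 3 with 8% sits well beyond the scatter of both. Going by the values given here, the single measured step between neighbouring structures is a number 28.3 percentage points lower from compound 2 to compound 3 (beyond the scatter).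

Compound 4 `CN1C[C@@H](c2ccco2)[C@@]2(Cc3ccccc3C2=O)[C@@]12C(=O)Nc1ccccc12` differs from compound 1 in one place: furan-2-yl in place of phenyl on a saturated ring carbon. Among the compounds with values here, no measured step in this assay touches the group on that saturated ring carbon; the only step available, the one from compound 2 to compound 3, concerns a substituent on an aromatic carbon and so does not bear on the present change. What the shared core with a phenyl at that position gives is known from compound 1; a smaller heteroaromatic ring there has not been examined.

With nothing comparable to lean on, only a cautious expectation is possible: compound 4 is estimated at 32%, with a plausible range from 14% to 50%, which means an expected step of a number 8 percentage points lower from compound 1 to compound 4 (within the scatter), not clearly beyond the scatter.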

Compound 4, a percentage reported as inhibition, in the whole organism at one dose (the size of the read-out at that dose, not a potency): 53.6%
Compound 4: the middle estimate sits 21.6 percentage points below what was measured; measured number outside the range, above it.
By their numbers in this assay, from the lowest: compound 3; then compounds 2 and 1 (each within the scatter of the next); then compound 4.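

In this assay the saturated ring carbon now has a measured step of its own: furan-2-yl in place of phenyl gives a number 13.6 percentage points higher from compound 1 to compound 4 (beyond the scatter), a modest change but one that stands clear of the usual scatter. The aromatic ring at this position therefore need not be a six-membered ring of carbon only, since a five-membered ring with one oxygen not only keeps the inhibition at this dose but raises it. The swap changes the ring size and brings in a hetero atom and a hydrogen-bond acceptor all at once, and nothing available separates these changes or explains the gain.

Thiophen-2-yl, with sulfur in place of the oxygen, and furan-3-yl, with the same ring attached through a different carbon, would help show whether the gain depends on the oxygen and on how the ring is attached, while a pyridine ring would test a six-membered aromatic ring that contains nitrogen. On these data alone, it also remains open whether furan-2-yl gives a similar gain on the core of compound 2, which carries a methyl group on the amide nitrogen.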